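A few compounds are considered here, and "the series" means these few. Any claim that something is new, unique, unknown or untested is made for them only; others in the source may bear on it.

Measured so far in a functional assay on HCT-116 cells (Homo sapiens) for inhibition, read by luminescence and resazurin assay, with a stated time of 3 days; a lower number here means a stronger inhibitor, a higher number a weaker inhibitor:

compound 1, `C=CCNc1nc(NCc2ccc(C(=O)Nc3ccc(F)cc3)cc2)c2ccccc2n1`: 14000 nM
compound 2, `C=CCNc1nc(NCc2ccc(C(=O)Nc3ccc(F)cc3)cc2)c2cc(C)ccc2n1`: 13000 nM

Compound 1 gives the highest of the two numbers in this assay, its nearest neighbour being compound 2 at a 1.1-fold lower number from compound 1 to compound 2 (0.03 log units; within the scatter), a step that stays within the scatter. Within the data shown here, the only measured step is therefore that one, methyl in place of hydrogen on an aromatic carbon, and it shows no movement beyond noise.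

Compound 3, `CNc1nc(NCc2ccc(C(=O)Nc3ccc(F)cc3)cc2)c2ccccc2n1`, differs from compound 1 as follows: hydrogen in place of vinyl on a saturated chain carbon bound to a nitrogen on an aromatic ring. Among the measured compounds shown here, no measured pair touches this position, so nothing on hand bears directly on it; the one available step only shows that a small change elsewhere on the core left the number where it was. With no evidence for a shift in either direction, compound 3 is expected to stay near compound 1, with an estimated step of no change at the digits printed from compound 1 to compound 3 (within the scatter). The estimate for compound 3 in this assay is 14000 nM, within a range of 5000 nM to 40000 nM.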

Compound 3, half-maximal inhibitory concentration: 2900 nM
For compound 3 the middle estimate is 4.8-fold (0.68 log units) above the measured one, and the stated range ends above it.
By their numbers in this assay, from the lowest: compound 3; then compounds 2 and 1 (each within the scatter of the next).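

The change from allylamino to methylamino gives, in this assay, a 4.8-fold lower number from compound 1 to compound 3 (0.68 log units; beyond the scatter) and is modest in size. Unlike the methyl change on the aromatic carbon in compound 2, it moves the number beyond the scatter, so this position, the first of the two probed to do so, is not indifferent to what the chain carries. No available data give a reason for the step.

A propyl group here would separate the loss of the double bond from the shortening of the chain, while an ethyl group or the free amine would show whether the number keeps falling as the chain gets shorter. Also open, as far as these compounds go, is whether the methyl on the aromatic carbon stays without effect when the methylamino group of compound 3 is present.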